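Extending a hydroxyethyl carbonate toward a tert-butyl ester

The source may report more compounds than this note shows. Statements on the series, on what has been measured and on what is new or still open speak of the compounds shown alone.

Of the compounds shown here, three sharing one core have been measured in a physicochemical assay for lipophilicity; on this read-out higher numbers stand for higher lipophilicity and lower numbers for lower lipophilicity. Compound 1 `Cc1cn(C2CC(N=[N+]=[N-])C(COC(=O)CCCC(=O)OC(C)(C)C)O2)c(=O)[nH]c1=O` gives 1.17 in this assay. Compound 2 `Cc1cn(C2CC(N=[N+]=[N-])C(COC(=O)OCCO)O2)c(=O)[nH]c1=O` gives -1.2 in this assay, the lowest of the three numbers; compound 3 `Cc1cn(C2CC(N=[N+]=[N-])C(COC(=O)NCCCC(=O)OC(C)(C)C)O2)c(=O)[nH]c1=O` gives 0.88 in this assay, and both compound 1 and compound 3 stand beyond the scatter above compound 2. Among the measured compounds shown here, the one step available between compounds that differ in a single place is a number 2.37 log units lower from compound 1 to compound 2 (beyond the scatter).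

The step now followed goes from compound 2 to compound 4 `Cc1cn(C2CC(N=[N+]=[N-])C(COC(=O)OCCCC(=O)OC(C)(C)C)O2)c(=O)[nH]c1=O`, which has not yet been measured in this assay. The change is (tert-butoxycarbonyl)methyl in place of hydroxy on a saturated chain carbon, two bonds along the chain from an oxygen next to a carbonyl group. Read one bond further out, it is 2-hydroxyethyl to 3-(tert-butoxycarbonyl)propyl, which is almost the mirror of the one measured step, run in the opposite direction, since compound 1 carries the 3-(tert-butoxycarbonyl)propyl on a carbonyl carbon while compound 2 carries the 2-hydroxyethoxy. That step was large and downward; a large upward step is therefore expected here, because a number 2.37 log units lower from compound 1 to compound 2 (beyond the scatter) suggests that reversing the exchange should give back most of the difference. Compound 4 is expected to reach 0.9 in this assay, within 0.3 to 1.5, an estimated step of a number 2.10 log units higher from compound 2 to compound 4 (beyond the scatter).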

Compound 4, partition coefficient: 1.14
Estimate against measurement, compound 4: 0.24 log units below; measured number inside the range.
By their numbers in this assay, from the lowest: compound 2; then compounds 3, 4 and 1 (each within the scatter of the next).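

Compound 4 keeps the carbonate of compound 2, so the move of a number 2.34 log units higher from compound 2 to compound 4 (beyond the scatter) in this assay is a change at one place only: hydroxy leaves and (tert-butoxycarbonyl)methyl enters on the saturated chain carbon. The earlier step, a number 2.37 log units lower from compound 1 to compound 2 (beyond the scatter), changed the carbonate against the ester as well as the chain end, so it could not show that the chain end alone is enough for a large step. Compound 4 (1.14) now also allows a comparison among the tert-butyl esters, and it stands within the scatter of both compound 3 (0.88), a carbamate, and compound 1 (1.17), an ester, so these three links cannot be told apart on this read-out.

No supporting measurement accounts for the size of the step. As far as these compounds go, it remains open how much of the step belongs to the tert-butyl group and how much to the chain, and a carboxylic acid at the chain end or a shorter chain ending in a methyl ester would be needed to separate the two.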